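The source may report more compounds than this note shows. Statements on the series, on what has been measured and on what is new or still open speak of the compounds shown alone.

Three compounds built on a shared core were tested in a functional assay on CCRF-CEM cells (Homo sapiens) for cytotoxicity, read by cell counting, with a stated time of 3 days; a lower number here means a stronger inhibitor, a higher number a weaker inhibitor. Compound 1 `CCN1C(=O)S/C(=C\c2ccc(N)cc2)C1=O` gives 91000 nM. Compound 2 `Nc1cccc(/C=C2\SC(=O)N(Cc3cccc(F)c3)C2=O)c1` gives 250000 nM, and compound 3 `Nc1ccc(/C=C2\SC(=O)N(Cc3cccc(F)c3)C2=O)cc1` gives 116000 nM; compound 3 thus has the second highest of the three numbers, nearest to compound 1 and furthest from compound 2. Compound 4 `CN1C(=O)S/C(=C\c2ccc(N)cc2)C1=O` is not yet measured; it differs from compound 3 by hydrogen in place of 3-fluorophenyl on a saturated chain carbon bound to an amide-type nitrogen in a ring. The step of a 1.3-fold higher number from compound 1 to compound 3 (0.11 log units; within the scatter) made the reverse kind of change at the same place and stayed within the scatter, while the step of a 2.2-fold lower number from compound 2 to compound 3 (0.33 log units; beyond the scatter) concerned a different place. Compound 4 is therefore expected to show no step beyond the scatter, a 1.2-fold lower number from compound 3 to compound 4 (0.06 log units; within the scatter). Compound 4 is estimated at 100000 nM, between 50000 nM and 220000 nM.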

Compound 4, half-maximal inhibitory concentration: 62000 nM
Compound 4: the middle estimate sits 1.6-fold (0.21 log units) above what was measured, and the stated range covers the measured number.
By their numbers in this assay, from the lowest: compounds 4, 1 and 3 (each within the scatter of the next); then compound 2.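

At this place, on a saturated chain carbon bound to an amide-type nitrogen in a ring, losing the 3-fluorophenyl group with its 7 heavy atoms stays within the scatter in this assay (a 1.9-fold lower number from compound 3 to compound 4 (0.27 log units; within the scatter)). Hydrogen in place of methyl at the same place also stays within the scatter (a 1.5-fold lower number from compound 1 to compound 4 (0.17 log units; within the scatter)). Thus, the three compounds with this change at this place cannot be told apart here, and no evidence available explains why. Going by these compounds, whether a larger change, such as a carboxylic acid or an amine on this chain, would move the number beyond the scatter remains open.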